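Phenylsulfanyl in Place of Phenethyl on a Shared Core

This account rests on a few compounds, and the source may have more. Where it says the series, first, only, none or still open, it means among the compounds named here.

Compound 3 `COc1cc(OCc2cccc(CCc3ccccc3)c2)c2cc(-c3cn4nc(OC)sc4n3)oc2c1` gives 68% in an ADME assay on microsomes from liver (Rattus norvegicus) for metabolic stability, with a stated time of 10 min (a lower number here means that less of the compound is left, a higher number that more of the compound is left), the highest of the three numbers recorded. Compound 1 `COc1cc(OCc2cccc(COc3ccccc3)c2)c2cc(-c3cn4nc(OC)sc4n3)oc2c1` gives 64% in this assay, and the step of a number 4 percentage points higher from compound 1 to compound 3 (within the scatter) lies within the scatter, so the two cannot be ordered. Compound 2 `COc1cc(OCc2cccc(O)c2)c2cc(-c3cn4nc(OC)sc4n3)oc2c1` gives 49%; the step of a number 19 percentage points higher from compound 2 to compound 3 (beyond the scatter) is modest but beyond the scatter, as is a number 15 percentage points lower from compound 1 to compound 2 (beyond the scatter).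

Compound 4 `COc1cc(OCc2cccc(Sc3ccccc3)c2)c2cc(-c3cn4nc(OC)sc4n3)oc2c1` differs from compound 3 by phenylsulfanyl in place of phenethyl on an aromatic carbon. The measured step that bears on this change is a number 4 percentage points higher from compound 1 to compound 3 (within the scatter), in which phenoxy gave way to benzyl at the same place without a shift beyond the scatter. Phenylsulfanyl is a further variant of the same attached phenyl group, and the only marked losses seen so far came with the hydroxy compound 2. Compound 4 is therefore expected to show no step beyond the scatter, a number 5 percentage points lower from compound 3 to compound 4 (within the scatter). Compound 4 is estimated at 63%, with an expected range from 48% to 78%.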

Compound 4, percent of the compound remaining: 45%
Compound 4: middle estimate off by 18 percentage points, on the high side, and the stated range ends above it.
By their numbers in this assay, from the lowest: compounds 4 and 2 (each within the scatter of the next); then compounds 1 and 3 (each within the scatter of the next).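

In this assay, this place on the aromatic ring does not treat every group carrying a phenyl ring alike: the change to phenylsulfanyl gives a number 23 percentage points lower from compound 3 to compound 4 (beyond the scatter) and also a number 19 percentage points lower from compound 1 to compound 4 (beyond the scatter). The loss is also no longer confined to the hydroxy group, as the step to phenylsulfanyl from that group is a number 4 percentage points lower from compound 2 to compound 4 (within the scatter), so a group that keeps the six-membered aromatic ring can end up level with it. Nothing available here explains why phenylsulfanyl and phenethyl part in this way.

Going by these compounds, it remains open whether the loss follows the sulfur atom or the way the phenyl ring is attached, a question on which an anilino or a phenylsulfonyl group at this place would bear. On these data alone, it is also open whether a longer chain carrying the phenyl ring would hold the higher numbers.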